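The compounds below may be only part of what the source reports. "The series", "measured", "known", "first", "only" and "open" are said of these compounds alone.

Measured compounds:
compound 1 `O=C1[C@@H](NS(=O)(=O)c2cc3c(Cl)nccc3s2)CCN1CCNc1ccncc1` — 39%
compound 2 `O=C1[C@@H](NS(=O)(=O)c2nc3cc(Cl)ccc3[nH]2)CCN1Cc1cc2c[nH]ccc-2n1` — 31%
compound 3 `O=C1[C@@H](NS(=O)(=O)c2nc3cc(Cl)ccc3[nH]2)CCN1Cc1cc2[nH]cccc-2n1` — 14%

In an assay on isolated protein for inhibition of coagulation factor X (Oryctolagus cuniculus), tested at 1 uM (on this read-out higher numbers stand for more inhibition at the one concentration tested (going by the name of the read-out) and lower numbers for less inhibition), compound 2 stands in the middle of the three numbers. Its value and that of compound 1 lie within the usual scatter of each other; compound 1 differs from compound 2 in more than one place, so only the two values themselves can be compared. Towards compound 3 the picture is different: a number 17 percentage points lower from compound 2 to compound 3 (beyond the scatter), a change on the saturated chain carbon bound to the amide-type nitrogen in the ring.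

Compound 4 `O=C1[C@@H](NS(=O)(=O)c2cc3c(Cl)nccc3s2)CCN1Cc1cc2c[nH]ccc-2n1` is unmeasured. It differs from compound 2 at the sulfonyl sulfur: a group of 10 heavy atoms (7 carbon, 1 nitrogen, 1 sulfur, 1 chlorine; one five-membered aromatic ring with 1 hetero atom, one six-membered aromatic ring with 1 hetero atom) in place of a group of 10 heavy atoms (7 carbon, 2 nitrogen, 1 chlorine; one five-membered aromatic ring with 2 hetero atoms, one six-membered aromatic ring of carbon only), on a sulfonyl sulfur

Among the compounds with values here, no measured step touches the sulfonyl group; the only measured step concerns the other end of the core. The same group as that of compound 4 sits on the sulfonyl sulfur of compound 1, and compound 1 gives 39%, a value within the scatter of compound 2. The expectation is therefore no step beyond the scatter, a number 6 percentage points higher from compound 2 to compound 4 (within the scatter). Compound 4 is estimated at 37%, with a range from 20% to 56%.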

Compound 4, a percentage reported as inhibition, at one concentration (the size of the read-out at that concentration, not a potency): 35%
Beside the measured number, compound 4's estimate is 2 percentage points above it; low and high end bracket the measured number.
By their numbers in this assay, from the lowest: compound 3; then compounds 2, 4 and 1 (each within the scatter of the next).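

In this assay, the sulfonyl sulfur now has its first measured step, a number 4 percentage points higher from compound 2 to compound 4 (within the scatter), so the exchange of 5-chloro-1H-benzimidazol-2-yl for the group of compound 4 on this sulfonyl sulfur leaves the read-out within the scatter. Within the data shown here, on the saturated chain carbon bound to an amide-type nitrogen in a ring, where the only earlier step lay beyond the scatter, a different exchange gives a number 4 percentage points lower from compound 1 to compound 4 (within the scatter), also within the scatter, so not every change there moves the read-out beyond it. No measurement available here offers an explanation for either step.

The compounds shown leave open whether a simple phenyl group, or a group carrying a carboxylic acid, on the sulfonyl sulfur would also stay within the scatter. They also leave open whether the group of compound 3 lowers the read-out to the same extent when the group of compound 4 sits on the sulfonyl sulfur.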